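From compound 1 to compound 4: one side group changes

A few compounds are considered here, and "the series" means these few. Any claim that something is new, unique, unknown or untested is made for them only; others in the source may bear on it.

Values measured so far in an ADME assay on liver for metabolic stability, with Liver microsome (Homo sapiens) as the target, using microsomes and NADPH, with a stated time of 30 min, tested at 0.5 uM (a higher number here means faster removal of the compound, a lower number slower removal), are these
compound 1 `CN1CCN(CCOc2nn(-c3ccccc3F)c3ccc(F)cc23)C1=O` gives 1000 mL/min/kg
compound 2 `O=C1N(Cc2ncco2)CCN1c1cccc2c1cnn2-c1ccccc1F` gives < 33.4 mL/min/kg as a limit of the assay
compound 3 `CC(C)(O)CC(=O)N1CC[C@H]2CN(c3cccc4c3cnn4-c3ccccc3F)C(=O)[C@H]21` gives 58.3 mL/min/kg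

Of the two true numbers, compound 1 at 1000 mL/min/kg is the higher one, and compound 3 at 58.3 mL/min/kg lies lower by more than the usual scatter of repeat measurements. The entry for compound 2 is a limit and not a number.

Compound 4 `Fc1ccc2c(c1)c(OCCn1ccnc1)nn2-c1ccccc1F` keeps the core of compound 1 and changes one group. It carries 1H-imidazol-1-yl in place of 3-methyl-2-oxoimidazolidin-1-yl on a saturated chain carbon, two bonds along the chain from an oxygen on an aromatic ring. Among the compounds with values here, no two measured compounds here differ in one place only, so this swap has no direct measured precedent.

The expectation therefore rests on the starting point. Compound 1 with its 1000 mL/min/kg sits so high in this assay that a fall is expected to be likelier than a rise, and a moderate fall beyond the scatter seems the best guess. The estimate means a 4.0-fold lower number from compound 1 to compound 4 (0.60 log units; beyond the scatter) as the expected change. For compound 4 the expected clearance is 250 mL/min/kg as a central estimate, with a range from 60 mL/min/kg to 1000 mL/min/kg as the likely span.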

Compound 4, clearance: 150 mL/min/kg
Beside the measured number, compound 4's estimate is 1.7-fold (0.22 log units) above it; the measured number falls inside the stated range.
By their numbers in this assay, from the lowest: compound 3; then compound 4; then compound 1. At a limit, below all of these: compound 2.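

Within the data shown here, the swap of 3-methyl-2-oxoimidazolidin-1-yl for 1H-imidazol-1-yl gives a 6.7-fold lower number from compound 1 to compound 4 (0.82 log units; beyond the scatter) in this assay, and this is the first step here that can be read across a single change. With the core of compound 1 left as it is, the group on this saturated chain carbon, two bonds along the chain from an oxygen on an aromatic ring, is enough on its own to move the clearance beyond the scatter. The position is therefore not a silent one in this assay, and a non-aromatic five-membered ring can give way to a smaller five-membered aromatic ring with a lower number as the result.

This single step cannot separate the aromatic ring from the loss of the carbonyl or the methyl, and nothing measured here gives a reason for the fall. On these data alone, how a dimethylamino group or a carboxylic acid at the end of this chain would read remains open, as does whether 1H-imidazol-1-yl on a longer chain would give a lower or a higher number.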